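Thiourea to Urea on a Fused Bicyclic Core

A few compounds are considered here, and "the series" means these few. Any claim that something is new, unique, unknown or untested is made for them only; others in the source may bear on it.

The measured compounds:
Compound 1 `NC(=O)c1c(NC(=O)c2ccccc2F)sc2c1CCN(C(=S)Nc1ccccc1Cl)C2`: in a functional assay on HeLa cells (Homo sapiens) for antiproliferative activity, with a stated time of 24 h (on this read-out lower numbers stand for stronger inhibition and higher numbers for weaker inhibition), compound 1 gives 19400 nM.
Compound 2 `NC(=O)c1c(NC(=O)c2ccccc2F)sc2c1CCN(C(=O)Nc1ccccc1Cl)C2`: in this assay compound 2 gives > 50000 nM, which is a limit of the assay and not a number.
Compound 3 `Cc1ccc(C(=O)Nc2sc3c(c2C(N)=O)CCN(C(=S)Nc2ccccc2Cl)C3)cc1`: in this assay compound 3 gives 26300 nM.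

Compound 1 and compound 2 share a core and differ by a group of 10 heavy atoms (7 carbon, 1 nitrogen, 1 oxygen, 1 chlorine; one six-membered aromatic ring of carbon only) in place of a group of 10 heavy atoms (7 carbon, 1 nitrogen, 1 sulfur, 1 chlorine; one six-membered aromatic ring of carbon only), on an amine nitrogen in a ring. This change gave an at least 2.5-fold higher number from compound 1 to compound 2 (0.41 log units; beyond the scatter), and the size of that step is capped by the limit of > 50000 nM in this assay, at which 1 of the 3 values shown sits.

The core of compound 3 differs from that of compound 1 by 4-methylphenyl in place of 2-fluorophenyl on a carbonyl carbon, a change that gave a 1.4-fold higher number from compound 1 to compound 3 (0.13 log units; within the scatter).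

Compound 4 `Cc1ccc(C(=O)Nc2sc3c(c2C(N)=O)CCN(C(=O)Nc2ccccc2Cl)C3)cc1` has not been measured. It stands to compound 3 as compound 2 stands to compound 1: the difference is a group of 10 heavy atoms (7 carbon, 1 nitrogen, 1 oxygen, 1 chlorine; one six-membered aromatic ring of carbon only) in place of a group of 10 heavy atoms (7 carbon, 1 nitrogen, 1 sulfur, 1 chlorine; one six-membered aromatic ring of carbon only), on an amine nitrogen in a ring, at the same place as before, so it is the same change made on the other core.

Because the first occurrence gave an at least 2.5-fold higher number from compound 1 to compound 2 (0.41 log units; beyond the scatter) and compound 3 sits at 26300 nM, the account expects compound 4 to move by about a 2.7-fold higher number from compound 3 to compound 4 (0.43 log units; beyond the scatter) in this assay. Compound 4 is therefore estimated at 70000 nM, with an expected range from 35000 nM to 150000 nM, and a fair chance that only a limit is reported.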

Compound 4, half-maximal inhibitory concentration: 32900 nM
Estimate against measurement, compound 4: 2.1-fold (0.33 log units) above, and the stated range ends above it.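

On the core of compound 3, (2-chlorophenyl)carbamoyl in place of the sulfur-bearing group on the amine nitrogen in a ring gave a 1.3-fold higher number from compound 3 to compound 4 (0.10 log units; within the scatter) in this assay, so on this core the change brought no step beyond the scatter, whereas on the core of compound 1 it did. This does not show that the change behaves differently on the two cores, and it does not show that it carries over unaltered, for the comparison stays undecided: the same change on two cores in this assay, an at least 2.5-fold higher number (0.41 log units; beyond the scatter) from compound 1 to compound 2 and a 1.3-fold higher number (0.10 log units; within the scatter) from compound 3 to compound 4; the limit leaves it open whether they differ The reverse view of the same four compounds, 4-methylphenyl in place of 2-fluorophenyl with (2-chlorophenyl)carbamoyl on the ring nitrogen, gave an at least 1.5-fold lower number from compound 2 to compound 4 (0.18 log units; that floor lies within the scatter), and it too cannot establish whether that exchange depends on the group at the other end of the molecule: the same change on two cores in this assay, a 1.4-fold higher number (0.13 log units; within the scatter) from compound 1 to compound 3 and an at least 1.5-fold lower number (0.18 log units; that floor lies within the scatter) from compound 2 to compound 4; the limit leaves it open whether they differ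

The compounds leave open the true size of every step that ends or starts at compound 2, whose value is only a limit of the assay: the limit of > 50000 nM in this assay, at which 1 of the 4 values shown sits. They also leave open how the exchange on the ring nitrogen behaves when the carbonyl carbon carries something other than these two phenyl groups, such as a longer chain or a phenyl ring bearing an amine or a carboxylic acid.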